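A few compounds are considered here, and "the series" means these few. Any claim that something is new, unique, unknown or untested is made for them only; others in the source may bear on it.

Measured so far:
compound 1, `CN(C[C@H]1Cc2c(cccc2N2CCN(Cc3ccccn3)CC2)CN1)[C@H]1CCCc2cccnc21`: 4.47 nM
compound 2, `CCCN(C[C@H]1Cc2c(cccc2N2CCNCC2)CN1)[C@H]1CCCc2cccnc21`: 32.2 nM
compound 3, `CN(C[C@@H]1Cc2c(cccc2N2CCNCC2)CN1)[C@H]1CCCc2cccnc21`: 313 nM

In a functional assay on CCRF-CEM cells for antagonist activity at C-X-C chemokine receptor type 4 (Homo sapiens), read by calcium flux, with stated times of 25 min and 90 s (on this read-out lower numbers stand for stronger inhibition and higher numbers for weaker inhibition), compound 1 gives the lowest of the three numbers, and both other compounds sit beyond the scatter from it: compound 2 gives 32.2 nM and compound 3 gives 313 nM. Compound 1 is therefore the most potent of the three measured compounds.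

Compound 4, `CCN1CCN(c2cccc3c2C[C@H](CN(C)[C@H]2CCCc4cccnc42)NC3)CC1`, has not yet been measured. It keeps the core of compound 1 and differs in one place: methyl in place of pyridin-2-yl on a saturated chain carbon bound to an amine nitrogen in a ring. Cut one bond further out, the change reads as ethyl in place of (pyridin-2-yl)methyl on the amine nitrogen in a ring.

Within the data shown here, no measured pair shows exactly this change, so the expectation rests on the spread of the three numbers. Compound 2 and compound 3, which carry no group at all on that ring nitrogen, both give weaker numbers than compound 1; compound 4 keeps a small group there. A modest loss is expected, with the step of a 3.4-fold higher number from compound 1 to compound 4 (0.53 log units; beyond the scatter) estimated to lie beyond the scatter. Compound 4 is expected to give about 15 nM, most likely between 4 nM and 60 nM.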

Compound 4, half-maximal inhibitory concentration: 13.8 nM
Compound 4: middle estimate off by 1.1-fold (0.04 log units), on the high side; the range from low to high includes it.
By their numbers in this assay, from the lowest: compound 1; then compound 4; then compound 2; then compound 3.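

In this assay, among these compounds, the step from (pyridin-2-yl)methyl to ethyl on the amine nitrogen in a ring is a 3.1-fold higher number from compound 1 to compound 4 (0.49 log units; beyond the scatter), the first change in this set that can be read at this position on its own. The loss is real but modest: even without the pyridin-2-yl ring, compound 4 still gives 13.8 nM, so this ring adds to the potency of compound 1 but is not needed for a low nanomolar value. Nothing shown here explains the size of this step.

The result cannot tell whether the ring itself or its nitrogen matters, and a benzyl group at this position would separate the two. From the compounds shown here alone, how a longer chain such as butyl or a carboxylic acid would fare here also remains open.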